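Pyridone series: cyclobutyl for isopropyl, liver clearance

The source may report more compounds than this note shows. Statements on the series, on what has been measured and on what is new or still open speak of the compounds shown alone.

Measured so far in an ADME assay on microsomes from liver (Homo sapiens) for metabolic stability; on this read-out higher numbers stand for fast clearance and lower numbers for slow clearance:
compound 1 `CC(C)n1cc(-c2ccnc3[nH]c(C4CCN(CC(=O)N(C)C)CC4)cc23)cnc1=O` gives 24 uL/min
compound 2 `CC(C)n1cc(-c2ccnc3[nH]c(C4CCN(CC(=O)N(C)C)CC4)cc23)ccc1=O` gives < 3 uL/min

Compound 2 returns only a limit in this assay, < 3 uL/min, and so sits at the limit of < 3 uL/min in this assay, at which 1 of the 2 values shown sits, with no number of its own. Among the compounds with values here, the one measured step, an at least 8.0-fold lower number from compound 1 to compound 2 (0.90 log units; beyond the scatter), changes the six-membered aromatic ring of compound 1 to that of compound 2 and leaves the substituent on the aromatic nitrogen untouched.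

Compound 3 `CN(C)C(=O)CN1CCC(c2cc3c(-c4ccc(=O)n(C5CCC5)c4)ccnc3[nH]2)CC1` differs from compound 2 by cyclobutyl in place of isopropyl on an aromatic nitrogen. Within the data shown here, no measured pair varies that group, so the measured step does not bear on this change, and there is no ground for expecting a step beyond the scatter in this assay in either direction. Compound 3 is therefore expected to stay near the limit at which compound 2 sits, with the step from compound 2 estimated as a number no lower from compound 2 to compound 3 (the limit leaves the size open). The estimate for compound 3 in this assay is 3 uL/min, within a range of 1.5 uL/min to 8 uL/min, with a fair chance that only a limit is reported again.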

Compound 3, intrinsic clearance in a liver preparation (reported as CLH), per the amount of preparation that the assay uses: < 3 uL/min
Compound 3: no number, only a limit; the forecaster's own chance of this, stated with the estimate: 55%; the middle value lies on the limit itself.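

In this assay compound 2 and compound 3 both return only a limit, so no step for cyclobutyl in place of isopropyl on an aromatic nitrogen can be read between them: the limit of < 3 uL/min in this assay, at which 2 of the 3 values shown sit.

The compounds shown leave open whether compound 2 and compound 3 differ at all in clearance, and by how much.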